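From a Free Hydroxy to a Methoxy Group

The source may hold more compounds than are shown below. What is called first, only, known or untested is meant among the compounds shown, and "the series" means these compounds.

Of the compounds shown here, two have so far been tested in a functional assay on the whole organism (Ear, strain ICR) for inhibition, with Mus musculus as the target, with stated times of 30 min and 2 h, at a dose of 1 umol/kg by the oral route; a lower number here means less inhibition, a higher number more inhibition at the dose given (going by the name of the read-out). Compound 1 `COC(=O)COc1ccc(/C=C/C(=O)CC(=O)/C=C/c2ccc(OC)c(OC)c2)cc1OC` gives 25.2%. Compound 2 `COc1cc(/C=C/C(=O)CC(=O)/C=C/c2ccc(OCC(=O)N[C@@H](CCCCN)C(=O)O)c(OC)c2)ccc1O` gives 41.1%, the higher of the two numbers, with a gap beyond the usual scatter; since these two compounds differ in more than one place, their values can only be set side by side. Compound 3 `COc1ccc(/C=C/C(=O)CC(=O)/C=C/c2ccc(OCC(=O)N[C@@H](CCCCN)C(=O)O)c(OC)c2)cc1OC` has not yet been measured. It differs from compound 2 in a single place: methyl in place of hydrogen on an oxygen on an aromatic ring, so the 4-hydroxy-3-methoxyphenyl end becomes a 3,4-dimethoxyphenyl end. Compound 1 also carries the 3,4-dimethoxyphenyl end and stands lower, but it differs elsewhere as well, so the weight of this change alone is uncertain. A modest fall is expected in this assay, a number 9.1 percentage points lower from compound 2 to compound 3 (within the scatter), with a fair chance of no change beyond the scatter. Compound 3 is estimated at 32%, within 15% to 48%.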

Compound 3, a percentage reported as inhibition, in the whole organism at one dose (the size of the read-out at that dose, not a potency): 39.3%
The estimate for compound 3 lay 7.3 percentage points below the measured number; the measured number falls inside the stated range.
By their numbers in this assay, from the lowest: compound 1; then compounds 3 and 2 (each within the scatter of the next).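

In this assay, turning the free hydroxy into a methoxy group gives a number 1.8 percentage points lower from compound 2 to compound 3 (within the scatter), so on this oxygen on an aromatic ring, methyl can stand in place of hydrogen with no change beyond the scatter. With the 3,4-dimethoxyphenyl end now the same on both sides, placing (5-amino-1-carboxypentyl)amino in place of methoxy on a carbonyl carbon gives a number 14.1 percentage points higher from compound 1 to compound 3 (beyond the scatter), which ties the lower number of compound 1 to that other end of the molecule and not to the 3,4-dimethoxyphenyl end. Nothing available explains the size of either step.

The compounds shown leave open whether a longer chain on this oxygen, such as ethyl or benzyl, would hold the number as methyl does, or whether an amine in place of the hydroxy would. Also open, on these data alone, is whether glycine in place of the (5-amino-1-carboxypentyl)amino part would keep the gain over compound 1.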